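The compounds below may be only part of what the source reports. "The series", "measured", "known", "first", "only" and "open" are said of these compounds alone.

In a functional assay on MDA-MB-231 cells (Homo sapiens) for inhibition, read by CCK-8 assay, with a stated time of 48 h (a higher number here means a weaker inhibitor of growth, a lower number a stronger inhibitor of growth), compound 1 `Cc1ccccc1Nc1nc(NC2CC2)ncc1Cl` gives > 100000 nM, which is a limit of the assay and not a number. Compound 2 `Cc1ccc(Nc2ncc(Cl)c(Nc3ccccc3C)n2)cc1` gives > 100000 nM, again a limit and not a number, so it has no exact position on the scale. The evidence so far amounts to the limit of > 100000 nM in this assay, at which 2 of the 2 values shown sit. Compound 3 `Cc1ccccc1Nc1nc(Nc2ccc(N3CCCCC3)cc2)ncc1Cl` carries piperidin-1-yl in place of methyl on an aromatic carbon, para to a large group: piperidin-1-yl in place of methyl on an aromatic carbon. Among the compounds with values here, the only measured step is a step that the two limits leave unreadable from compound 1 to compound 2, and it offers no size to carry over. Since a step that the two limits leave unreadable from compound 1 to compound 2 has no readable size, only a cautious expectation is possible: a modest strengthening of growth inhibition, or none that can be read. The expected change is an at least 3.3-fold lower number from compound 2 to compound 3 (0.52 log units; beyond the scatter). Compound 3 is estimated at 30000 nM, with an expected range from 3000 nM to 100000 nM.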

Compound 3, concentration for 50% growth inhibition: 19900 nM
For compound 3 the middle estimate is 1.5-fold (0.18 log units) above the measured one; the range from low to high includes it.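

In this assay, replacing methyl with piperidin-1-yl on an aromatic carbon, para to a large group, gives an at least 5.0-fold lower number from compound 2 to compound 3 (0.70 log units; beyond the scatter). Within the data shown here, this is the first readable step here, showing that this position accepts the larger ring and that this change can move a compound measurably on the scale, whereas the step from compound 1 to compound 2 cannot be read. Compound 3 is also the only one of the three with an exact value, while the other two remain at a limit and not a number: the limit of > 100000 nM in this assay, at which 2 of the 3 values shown sit.

The compounds shown cannot separate the contribution of the ring nitrogen from that of the added ring carbons, and a cyclohexyl group or a morpholin-4-yl group at the same place would address this. They also leave open whether a simple amine there would produce a similar step.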